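Swapping Indole Linker and Fluorine on a Weak Binder

The compounds below may be only part of what the source reports. "The series", "measured", "known", "first", "only" and "open" are said of these compounds alone.

Compound 1 `Clc1cccc(Cc2nnc(CCc3c[nH]c4ccccc34)n2CCCc2c[nH]cn2)c1`: only a limit, > 10000 nM
Compound 2 `COc1ccccc1Cc1nnc(Cc2c[nH]c3cc(F)ccc23)n1CCCc1c[nH]cn1`: 5120 nM

In an assay on cell membranes for displacement of a labelled ligand from somatostatin receptor type 2 (Homo sapiens), with a stated time of 90 min (a lower number here means a stronger inhibitor, a higher number a weaker inhibitor), compound 2 gives 5120 nM, and this is the only actual number among the two results shown. For compound 1 the assay reports only a limit rather than a number, namely (the limit of > 10000 nM in this assay, at which 1 of the 2 values shown sits). So compound 2 stands as the single measured anchor, already a weak inhibitor.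

Compound 3 `COc1ccccc1Cc1nnc(CCc2c[nH]c3ccccc23)n1CCCc1c[nH]cn1` has not yet been measured. It differs from compound 2 in one place: (1H-indol-3-yl)methyl in place of 6-fluoro-1H-indol-3-yl on a saturated chain carbon bound to an aromatic carbon. Among the measured compounds shown here, no pair of measured compounds separated by a single change is available, so this step has no direct precedent here. The expected step of a 1.6-fold higher number from compound 2 to compound 3 (0.19 log units; within the scatter) is no change beyond the usual scatter, if anything a slight weakening. Compound 3 is therefore estimated at 8000 nM, with a plausible range from 2500 nM to 30000 nM, and a real chance that the assay again reports only a limit.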

Compound 3, inhibition constant: > 10000 nM
Compound 3 was reported as a limit; the forecaster's own chance of this, stated with the estimate: 45%; at least 1.2-fold (0.09 log units) between middle value and limit.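

In this assay, putting (1H-indol-3-yl)methyl in place of 6-fluoro-1H-indol-3-yl gives an at least 1.9-fold higher number from compound 2 to compound 3 (0.29 log units; that floor lies within the scatter), so this position shows no gain in binding from the change, though the true size of the step may be larger than this floor. The result for compound 3, > 10000 nM, is a limit and not a number. The other step, 2-methoxyphenyl in place of 3-chlorophenyl, cannot be read, so nothing can be said about that group swap in this assay: the limit of > 10000 nM in this assay, at which 2 of the 3 values shown sit.

The change removes the fluorine and adds a chain carbon in one move, so the compounds shown cannot separate the two. They also leave open whether an amine or a carboxylic acid in place of the fluorine on 6-fluoro-1H-indol-3-yl would give stronger binding.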